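Dropping one chloro from the core of compound 2

The compounds below may be only part of what the source reports. "The series", "measured", "known", "first", "only" and "open" are said of these compounds alone.

Of the compounds shown here, two have been measured here. In a functional assay on SF-539 cells (Homo sapiens) for cytotoxicity, read by sulforhodamine B assay, with a stated time of 48 h (on this read-out higher numbers stand for lower toxicity in this test and lower numbers for higher toxicity in this test), compound 1 `ClCc1ccc(Cn2cnc3c(Cl)ncnc32)cc1` gives 70800 nM. Compound 2 `ClCc1ccccc1Cn1cnc2c(Cl)nc(Cl)nc21` gives 5620 nM in this assay, the lowest of the two numbers, and the higher number of compound 1 lies beyond the scatter of the test.

Compound 3 `ClCc1ccccc1Cn1cnc2c(Cl)ncnc21` is compound 2 with one change: hydrogen in place of chloro on an aromatic carbon. Within the data shown here, no pair of measured compounds isolates this single change, so its effect must be judged as an expectation. The only other measured point, compound 1 with 70800 nM, sits well above compound 2, and the removal of a chloro from the core is expected to move the number upward rather than leave it unchanged, by a step of a 4.4-fold higher number from compound 2 to compound 3 (0.65 log units; beyond the scatter). Compound 3 is therefore estimated at 25000 nM in this assay, within a range from 6000 nM to 80000 nM.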

Compound 3, concentration lethal to 50% of the cells: 55000 nM
Compound 3: the middle estimate sits 2.2-fold (0.34 log units) below what was measured, and the stated range covers the measured number.
By their numbers in this assay, from the lowest: compound 2; then compounds 3 and 1 (each within the scatter of the next).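

In this assay, the chloro on the aromatic carbon between two ring nitrogen atoms clearly counts: hydrogen in its place gives a 9.8-fold higher number from compound 2 to compound 3 (0.99 log units; beyond the scatter) and so means lower toxicity in this test. Among these compounds, compound 2 and compound 3 form the first measured pair that differs in this one place alone, so the shift can now be tied directly to this single change. Nothing measured here accounts for the size of this step.

As far as these compounds go, whether an amine, a methoxy group or a fluoro on this same aromatic carbon would give a number nearer that of compound 2 or that of compound 3 remains open. Also open, from the compounds shown here alone, is whether the same change would give a similar step on other cell types.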